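Freeing one hydroxy on a dichlorobenzyl ether

A few compounds are considered here, and "the series" means these few. Any claim that something is new, unique, unknown or untested is made for them only; others in the source may bear on it.

In a functional assay on MCF7 cells (Homo sapiens) for inhibition, read by MTT assay, with a stated time of 72 h (on this read-out lower numbers stand for stronger inhibition and higher numbers for weaker inhibition), compound 1 (`C=CCc1ccc(O)c(-c2ccc(OCc3ccccc3)c(CC=C)c2)c1`) gives 23200 nM, a measured value for a core that keeps one free hydroxy. Compound 2 (`C=CCc1ccc(OCc2ccc(Cl)cc2Cl)c(-c2ccc(OCc3ccc(Cl)cc3Cl)c(CC=C)c2)c1`), which carries a 2,4-dichlorobenzyl group on both oxygens, gives only a limit of the assay, > 50000 nM, and not a number. Its standing is therefore known only as the limit of > 50000 nM in this assay, at which 1 of the 2 values shown sits, so no exact gap to compound 1 can be stated.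

Compound 3 (`C=CCc1ccc(OCc2ccc(Cl)cc2Cl)c(-c2ccc(O)c(CC=C)c2)c1`) is reached from compound 2 through (hydrogen in place of 2,4-dichlorobenzyl on an oxygen on an aromatic ring). One (2,4-dichlorobenzyl)oxy group thus becomes hydroxy, while the other stays in place. Among the measured compounds shown here, no measured pair shows this change on its own, and two compounds establish no pattern. The nearest guide is compound 1, which also has one hydroxy and gives 23200 nM, so a number in the same region is expected. The expected step of an at least 2.5-fold lower number from compound 2 to compound 3 (0.39 log units; beyond the scatter) runs toward stronger inhibition in this assay, although its size remains uncertain with a limit at its start. For compound 3 the estimated value is 20000 nM, with an expected range of 8000 nM to 45000 nM.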

Compound 3, half-maximal inhibitory concentration: 27400 nM
Estimate against measurement, compound 3: 1.4-fold (0.14 log units) below, and the stated range covers the measured number.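

Among the compounds shown here, with compound 3, the change from (2,4-dichlorobenzyl)oxy to hydroxy can be read for the first time on a measured pair, and in this assay it gives an at least 1.8-fold lower number from compound 2 to compound 3 (0.26 log units; that floor lies within the scatter). Removing a single 2,4-dichlorobenzyl group is thus enough to yield a measured number, even though the second such group stays in place on the other oxygen. As far as these compounds go, the pair alone does not establish a gain beyond the scatter, and the true size of the step remains unknown because compound 2 has only a limit and no number: the limit of > 50000 nM in this assay, at which 1 of the 3 values shown sits.

The compounds shown leave open whether the same change on the other oxygen would give a similar result, and whether removing both 2,4-dichlorobenzyl groups would lead to a lower or a higher number. They also do not show how a methoxy group, an amine or a carboxylic acid in place of the freed hydroxy would read in this assay.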